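The source may hold more compounds than are shown below. What is called first, only, known or untested is meant among the compounds shown, and "the series" means these compounds.

Measured in a functional assay on K562 cells (Homo sapiens) for cytotoxicity, read by MTT assay, with a stated time of 5 days; a higher number here means a weaker inhibitor, a lower number a stronger inhibitor:
- compound 1 `COc1ccc(Cn2nncc2-c2cc(OC)c(OC)c(OC)c2)cc1Br`: > 10000 nM, a limit
- compound 2 `COc1ccc(-c2cn(-c3cc(OC)c(OC)c(OC)c3)nn2)cc1`: > 10000 nM, a limit
- compound 3 `COc1ccc(-c2cn(-c3cc(OC)c(OC)c(OC)c3)nn2)cc1O`: > 10000 nM, a limit

Compound 3 gives > 10000 nM, which is a limit and not a number. All of the data here sit at the limit of > 10000 nM in this assay, at which 3 of the 3 values shown sit.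

Next is compound 4 `COc1ccc(-c2cn(-c3cc(OC)c(OC)c(OC)c3)nn2)cc1N`, with amino in place of hydroxy on an aromatic carbon. For the measured compounds named here, the one measured step that bears on this change is a step that the two limits leave unreadable from compound 2 to compound 3, at the same aromatic carbon. It gives neither a size nor a direction for this assay, so the value is expected to stay near the limit, with no readable step foreseen. The expected step is an at least 1.1-fold lower number from compound 3 to compound 4 (0.04 log units; that floor lies within the scatter). For compound 4 the estimated value is 9000 nM, with an expected range of 2000 nM to 30000 nM.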

Compound 4, half-maximal inhibitory concentration: 1300 nM
For compound 4 the middle estimate is 6.9-fold (0.84 log units) above the measured one, and the stated range ends above it.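

In this assay, for the compounds shown here, amino on this aromatic carbon, ortho to a methoxy group, gives the only value shown that is not a limit. Amino in place of hydroxy gives an at least 7.6-fold lower number from compound 3 to compound 4 (0.88 log units; beyond the scatter), and amino in place of hydrogen gives an at least 7.6-fold lower number from compound 2 to compound 4 (0.88 log units; beyond the scatter). Hydroxy and amino count the same hydrogen-bond donors and acceptors yet do not behave alike here, while the step from hydrogen to hydroxy cannot be read.

From the compounds shown here alone, the true size of both steps stays open, as the other compounds sit at one limit: the limit of > 10000 nM in this assay, at which 3 of the 4 values shown sit. Whether a methylamino or acetamido group on the same carbon keeps this gain is also open.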